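The compounds below may be only part of what the source reports. "The series", "measured", "known", "first", "only" and "open" are said of these compounds alone.

Compound 2, `COc1ccc(C(=O)/C=C/c2cc(-c3cc(OC)c(OC)c(OC)c3)n[nH]2)cc1OC`, gives -13% in a functional assay on K562 cells (Homo sapiens) for cytotoxicity, read by sulforhodamine B assay, with a stated time of 48 h, tested at 10 uM (on this read-out lower numbers stand for a stronger effect and higher numbers for a weaker effect at the one concentration tested), the lower of the two numbers measured there. Within the data shown here, its only measured neighbour is compound 1, `COc1cc(-c2cc(/C=C/C(=O)c3ccc(N)cc3)[nH]n2)cc(OC)c1OC`, which in this assay gives 2%. Among the measured compounds shown here, the one measured step, a number 15 percentage points lower from compound 1 to compound 2 (beyond the scatter), exchanges the aryl group on the carbonyl carbon; it shows that changing this group can shift the read-out beyond the scatter, though only modestly.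

Compound 3, `COc1cc(-c2cc(/C=C/C(=O)c3ccc(F)c(F)c3)[nH]n2)cc(OC)c1OC`, differs from compound 2 at the same carbonyl carbon: 3,4-difluorophenyl in place of 3,4-dimethoxyphenyl on a carbonyl carbon. For the measured compounds named here, no measured step tells what a 3,4-difluorophenyl does in this place, so the expectation rests on the single step from compound 1 to compound 2 and its modest size. A step of comparable size in either direction, or none beyond the scatter, is plausible; a wide range is therefore allowed.

Compound 3 is estimated at -5% in this assay, within a range of -25% to 15%. This means an expected step of a number 8 percentage points higher from compound 2 to compound 3 (within the scatter), which lies within the scatter and is not expected to be a real change.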

Compound 3, a percentage reported as activity, at one concentration (the size of the read-out at that concentration, not a potency): 2%
For compound 3 the middle estimate is 7 percentage points below the measured one; low and high end bracket the measured number.
By their numbers in this assay, from the lowest: compound 2; then compounds 1 and 3 (each within the scatter of the next).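

The 3,4-difluorophenyl group on the carbonyl carbon gives a number 15 percentage points higher from compound 2 to compound 3 (beyond the scatter) in this assay, so a second step at this position lies beyond the scatter, and compound 2, with its 3,4-dimethoxyphenyl group, has the lowest number of the three compounds. The other new step shows no change at the digits printed from compound 1 to compound 3 (within the scatter), which means that the read-out does not separate the 3,4-difluorophenyl group from the 4-aminophenyl group at this position, and the effect of exchanging the aryl group here therefore depends on which groups are exchanged, with 3,4-dimethoxyphenyl the only one of the three that differs beyond the scatter from the other two. Nothing available explains why the 3,4-dimethoxyphenyl group stands apart from the other two.

The compounds shown leave open whether both methoxy groups are needed for the lower number, which a 4-methoxyphenyl or a plain phenyl on the carbonyl carbon would help to settle. They also leave open how this position responds to a group of another kind, such as a carboxylic acid or a morpholine, and whether the difference holds on the shared core when other parts of it change.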